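Adding a Nitro Group to the Core of Compound 3

The compounds below may be only part of what the source reports. "The series", "measured", "known", "first", "only" and "open" are said of these compounds alone.

Measured so far in an ADME assay on RAW264.7 cells (Mus musculus) for cytotoxicity, read by MTT assay, with a stated time of 48 h; a lower number here means a stronger inhibitor, a higher number a weaker inhibitor:
Compound 1, `CCS(=O)(=O)Nc1ccc(NC(=O)c2ccc(Cl)c([N+](=O)[O-])c2)cc1C`, gives 141000 nM.
Compound 2, `COc1cc(NC(=O)c2ccc(Cl)c([N+](=O)[O-])c2)ccc1NS(C)(=O)=O`, gives only a limit of the assay, > 250000 nM.
Compound 3, `CCS(=O)(=O)Nc1ccc(NC(=O)c2ccc(Cl)cc2)cc1OC`, gives 60100 nM.

Compound 3 stands lowest of the two numbers; its nearest neighbour is compound 1, whose value lies above it by a gap beyond the scatter. Compound 4, `CCS(=O)(=O)Nc1ccc(NC(=O)c2ccc(Cl)c([N+](=O)[O-])c2)cc1OC`, has not been measured. It differs from compound 3 by nitro in place of hydrogen on an aromatic carbon. For the measured compounds named here, no measured pair shares this change. Compound 1 carries the nitro group and gives 141000 nM. Compound 2 also carries it and gives only a limit, > 250000 nM. On that basis an upward step beyond the scatter is expected in this assay; the expected step is a 2.5-fold higher number from compound 3 to compound 4 (0.40 log units; beyond the scatter). Compound 4 is expected at 150000 nM, between 60000 nM and 400000 nM.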

Compound 4, half-maximal inhibitory concentration: 5660 nM
For compound 4 the middle estimate is 27-fold (1.42 log units) above the measured one; measured number outside the range, below it.
By their numbers in this assay, from the lowest: compound 4; then compound 3; then compound 1. At a limit, above all of these: compound 2.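

In this assay, nitro in place of hydrogen, ortho to a chloro group, brings an 11-fold lower number from compound 3 to compound 4 (1.03 log units; beyond the scatter), so this change can lower the number, which the two earlier nitro compounds did not show. The outcome also depends on the other groups, as methoxy in place of methyl gives a 25-fold lower number from compound 1 to compound 4 (1.40 log units; beyond the scatter). Methyl in place of hydrogen on the chain carbon bound to the sulfonyl sulfur gives an at least 44-fold lower number from compound 2 to compound 4 (1.64 log units; beyond the scatter), a step that starts from a limit of the assay: the limit of > 250000 nM in this assay, at which 1 of the 4 values shown sits.

As far as these compounds go, whether an amine or a nitrile at this position would give a similar step remains open. So does the effect of a longer chain on the sulfonyl sulfur.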